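Working notes on four related compounds

The source may hold more compounds than are shown below. What is called first, only, known or untested is meant among the compounds shown, and "the series" means these compounds.

Values in a functional assay for inhibition, with Homo sapiens as the target (a lower number here means a stronger inhibitor, a higher number a weaker inhibitor), for the measured compounds:
compound 1, `c1cc(Nc2nccc(-c3ccncc3)n2)cc(OCCn2ccnc2)c1`: 200 nM
compound 2, `c1cc(Nc2nccc(-c3cccnc3)n2)cc(OCCn2ccnc2)c1`: 100 nM
compound 3, `COc1ccc(N(C)c2nccc(-c3ccncc3)n2)cc1`: > 24000 nM, which is a limit of this assay and not a number.

The change from compound 1 to compound 2 is pyridin-3-yl in place of pyridin-4-yl on an aromatic carbon, and it made a 2.0-fold lower number from compound 1 to compound 2 (0.30 log units; within the scatter). The difference between the core of compound 1 and the core of compound 3 is not broken down here; compound 3 sits at the limit of > 24000 nM in this assay, at which 1 of the 3 values shown sits.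

Compound 4, `COc1ccc(N(C)c2nccc(-c3cccnc3)n2)cc1`, is not yet measured. It arises from compound 3 by the same change, (pyridin-3-yl in place of pyridin-4-yl on an aromatic carbon). Since the same change on compound 1 gave only a 2.0-fold lower number from compound 1 to compound 2 (0.30 log units; within the scatter), the step from compound 3 to compound 4 is expected to be of similar size, a number no higher from compound 3 to compound 4 (the limit leaves the size open). Compound 4 is therefore estimated to give about 24000 nM in this assay, expected between 10000 nM and 60000 nM, and most likely again only a limit.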

Compound 4, half-maximal inhibitory concentration: > 24000 nM
Compound 4: a limit, no number; the forecaster's own chance of this, stated with the estimate: 70%; the middle value lies on the limit itself.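

Compound 3 and compound 4 both sit at a limit of the assay and not at a number, so no step between them can be read: the limit of > 24000 nM in this assay, at which 2 of the 4 values shown sit.

Still open, as far as these compounds go, is which part of the difference between the core of compound 1 and the core of compound 3 separates their results.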